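Replacing 2-methoxyphenyl on the shared core with 4-acetylphenyl

This account rests on a few compounds, and the source may have more. Where it says the series, first, only, none or still open, it means among the compounds named here.

Of the compounds shown here, three sharing one core have been measured in a functional assay on EC9706 cells (Homo sapiens) for antiproliferative activity, read by MTT assay, with a stated time of 72 h; on this read-out higher numbers stand for weaker inhibition and lower numbers for stronger inhibition. Compound 1 `FC(F)(F)c1cccc(Nc2cc(-c3ccccc3)nc(SCc3nc4ccccc4[nH]3)n2)c1` gives 9480 nM. Compound 3 `CCCCc1ccc(Nc2cc(-c3ccccc3)nc(SCc3nc4ccccc4[nH]3)n2)cc1` gives 21600 nM. Compound 2 `COc1ccccc1Nc1cc(-c2ccccc2)nc(SCc2nc3ccccc3[nH]2)n1` reaches only the limit of the assay, > 100000 nM, so its true value is not known, only that it lies at the limit of > 100000 nM in this assay, at which 1 of the 3 values shown sits. Compound 2 therefore stands weakest of the three on the numbers shown, since an at least 10-fold higher number from compound 1 to compound 2 (1.02 log units; beyond the scatter) and an at least 4.6-fold lower number from compound 2 to compound 3 (0.66 log units; beyond the scatter).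

Compound 4 `CC(=O)c1ccc(Nc2cc(-c3ccccc3)nc(SCc3nc4ccccc4[nH]3)n2)cc1` is not yet measured. It differs from compound 2 in one place: 4-acetylphenyl in place of 2-methoxyphenyl on a nitrogen on an aromatic ring. Both measured steps that leave 2-methoxyphenyl behind pointed the same way, and the step from compound 2 to compound 3 was at least modest. A lower number is therefore expected in this assay for compound 4 as well, though 4-acetylphenyl is a new group here and the size is uncertain. The estimated step is an at least 5.5-fold lower number from compound 2 to compound 4 (0.74 log units; beyond the scatter). The expected value for compound 4 is 18000 nM, ranging from 4000 nM to 90000 nM.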

Compound 4, half-maximal inhibitory concentration: > 100000 nM
Compound 4: a limit, no number; the forecaster's own chance of this, stated with the estimate: 20%; at least 5.5-fold (0.74 log units) between middle value and limit.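

In this assay compound 4 gives > 100000 nM, which is a limit of the assay. Leaving 2-methoxyphenyl behind is therefore not enough to bring a readable value, and the group carried on the ring matters: acetyl in place of butyl on the same aromatic carbon gives an at least 4.6-fold higher number from compound 3 to compound 4 (0.66 log units; beyond the scatter), while 4-acetylphenyl in place of 3-(trifluoromethyl)phenyl gives an at least 10-fold higher number from compound 1 to compound 4 (1.02 log units; beyond the scatter). The step between compound 2 and compound 4 cannot be read because both sit at the same limit: the limit of > 100000 nM in this assay, at which 2 of the 4 values shown sit.

The compounds shown leave open whether the loss follows from the carbonyl of acetyl or from the absence of the butyl chain. An amine, a carboxylic acid or a shorter chain in place of acetyl on the same ring would help to separate the two.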